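The source may report more compounds than this note shows. Statements on the series, on what has been measured and on what is new or still open speak of the compounds shown alone.

Measured in a functional assay on Raji cells (Homo sapiens) for cytotoxicity, with a stated time of 72 h; on this read-out higher numbers stand for weaker inhibition and lower numbers for stronger inhibition:
Compound 1 `CCOC(=O)/C=C/C=C/c1ccc[nH]1`: > 10000 nM
Compound 2 `CCOC(=O)/C=C/C=C/C=C/C=C/c1ccc[nH]1`: 4090 nM
Compound 3 `CCOC(=O)/C=C/C=C/C=C/C=C/C=C/c1ccc[nH]1`: > 10000 nM

The series offers little to work from. In this assay, within the data shown here, compound 2 is the only compound with an actual number, at 4090 nM. Compound 1 gives > 10000 nM, which is a limit of the assay and not a number. Compound 3 gives > 10000 nM, which is likewise a limit.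

The next compound to be tested is compound 4 `CCOC(=O)/C=C/C=C/C=C/C=C/c1cccn1C`. It differs from compound 2 by methyl in place of hydrogen on an aromatic nitrogen. Among the measured compounds shown here, no measured pair shows this change, so its size cannot be read from the data. The working expectation is therefore modest, with no shift beyond the usual scatter and, if anything, a slight lean towards weaker inhibition. This expectation starts from compound 2 at 4090 nM. A result reported only as a limit would not be a surprise. The expected change is a 1.2-fold higher number from compound 2 to compound 4 (0.09 log units; within the scatter). For compound 4 the estimated value is 5000 nM, with an expected range of 1800 nM to 10000 nM.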

Compound 4, half-maximal inhibitory concentration: > 10000 nM
Compound 4: a limit, no number; the forecaster's own chance of this, stated with the estimate: 35%; at least 2.0-fold (0.30 log units) between middle value and limit.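

In this assay compound 4 gives > 10000 nM, a limit of the assay and not a number. Methyl in place of hydrogen on the aromatic nitrogen, the change from 1H-pyrrol-2-yl to 1-methyl-1H-pyrrol-2-yl, gives an at least 2.4-fold higher number from compound 2 to compound 4 (0.38 log units; beyond the scatter), which is the first measured step in the series and shows that this nitrogen matters for the read-out, whereas the earlier compounds differed only in their chain. Only a lower bound on the size of this step can be given, and how much further it goes cannot be read, because the value for compound 4 sits at the ceiling of the assay: the limit of > 10000 nM in this assay, at which 3 of the 4 values shown sit.

The compounds shown leave open whether the loss is specific to methyl or would also follow from another group on this nitrogen, such as ethyl or acetyl. They also leave open whether changes elsewhere on the core of compound 2, such as a carboxylic acid or an amide in place of the ethyl ester, would give a stronger number than compound 2 at 4090 nM.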